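The source may report more compounds than this note shows. Statements on the series, on what has been measured and on what is new or still open speak of the compounds shown alone.

Measured so far:
compound 1, `CCOC(=O)N1CCC(NS(=O)(=O)c2ccc(NC(=O)c3ccccc3)c3ccccc23)CC1`, 0.17 nM in an assay on L1.2 cells for binding affinity to C-C chemokine receptor type 8 (Homo sapiens); a higher number here means a weaker inhibitor, a lower number a stronger inhibitor
compound 2, `CCOC(=O)N1CCC(NS(=O)(=O)c2ccc(C(=O)NC3CCCCC3)c3ccccc23)CC1`, 9.5 nM
compound 3, `CCOC(=O)N1CCC(NS(=O)(=O)c2ccc(C(=O)Nc3ccccc3C)c3ccccc23)CC1`, 5.21 nM

Compound 3 stands second highest of the three numbers in this assay. Its nearest neighbour is compound 2, and the difference a 1.8-fold lower number from compound 2 to compound 3 (0.26 log units; within the scatter) lies within the scatter, so the two cannot be ordered. Its furthest neighbour is compound 1, from which the step of a 31-fold higher number from compound 1 to compound 3 (1.49 log units; beyond the scatter) is large.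

Compound 4, `CCOC(=O)N1CCC(NS(=O)(=O)c2ccc(NCc3ccccc3)c3ccccc23)CC1`, is not yet measured. It differs from compound 3 in one place: benzylamino in place of (2-methylphenyl)carbamoyl on an aromatic carbon. Going by the values given here, two measured steps bear on this. The step of a 56-fold higher number from compound 1 to compound 2 (1.75 log units; beyond the scatter) and the step of a 31-fold higher number from compound 1 to compound 3 (1.49 log units; beyond the scatter) both show that replacing benzamido by a carbamoyl group attached through carbon raised the number strongly; compound 4 returns to a group attached through nitrogen, as in compound 1, but without a carbonyl. Among the compounds with values here, no measured pair shows what removing that carbonyl does. Compound 4 is therefore expected to land between compound 3 and compound 1, with a step of a 2.6-fold lower number from compound 3 to compound 4 (0.42 log units; beyond the scatter) toward a lower number. The estimate for compound 4 is 2 nM, within 0.3 nM to 15 nM.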

Compound 4, inhibition constant: 45.6 nM
Compound 4: middle estimate off by 23-fold (1.36 log units), on the low side, outside the stated range (above it).
By their numbers in this assay, from the lowest: compound 1; then compounds 3 and 2 (each within the scatter of the next); then compound 4.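

In this assay, the change from benzoyl to benzyl on the nitrogen, with the step of a 270-fold higher number from compound 1 to compound 4 (2.43 log units; beyond the scatter), raises the number further than either carbamoyl replacement of benzamido did. Attachment through nitrogen alone therefore does not preserve the low number at this position: benzylamino also stands above both carbamoyl groups, with the steps of an 8.8-fold higher number from compound 3 to compound 4 (0.94 log units; beyond the scatter) and a 4.8-fold higher number from compound 2 to compound 4 (0.68 log units; beyond the scatter), so among these compounds the low number goes with the intact benzamido group. No supporting measurement bears on why removing the carbonyl has this effect.

The compounds shown leave open whether another carbonyl-bearing group on that nitrogen, such as acetyl or a phenylurea, would keep a number near that of compound 1. They also leave open how a methoxy group or a chlorine on the benzoyl ring would change it.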